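This account rests on a few compounds, and the source may have more. Where it says the series, first, only, none or still open, it means among the compounds named here.

Compound 1 `Cc1c(OCCCCOc2ccc(C(=O)C(C)C)c(O)c2C)cccc1C(=O)O` gives 149 nM in an assay on HEK293 cells for positive allosteric modulation of metabotropic glutamate receptor 2 (Rattus norvegicus), read by thallium flux, with a stated time of 2.5 min; a lower number here means that less compound is needed, a higher number that more compound is needed for the effect.
Compound 2 `Cc1c(OCCCCOc2ccc(F)c(C(=O)O)c2)ccc(C(=O)CC(C)(C)C)c1O` gives 208 nM in this assay.

Going by the values given here, of the two numbers recorded in this assay, compound 2 holds the higher one, yet its only neighbour, compound 1, differs from it by an amount that lies within the scatter of repeated measurements, so the two values show no real separation between them.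

Compound 3 `Cc1c(OCCCCOc2ccc(C(=O)CC(C)(C)C)c(O)c2C)cccc1C(=O)O` takes the step from compound 2 in which (3-carboxy-2-methylphenyl in place of 3-carboxy-4-fluorophenyl on an oxygen on a saturated carbon). The rest of compound 2 is kept unchanged, so compound 3 carries the 3-carboxy-2-methylphenyl already present in compound 1 together with the remainder of compound 2. Among the compounds with values here, no step between two measured compounds bears directly on this exchange; what the two measured values show is only that both compound 1 and compound 2 land in the same region of this assay. Compound 3 is therefore expected to sit close to both of them, and a 1.2-fold lower number from compound 2 to compound 3 (0.09 log units; within the scatter) is expected to be no step beyond the scatter in either direction. Compound 3 is estimated at 170 nM, with a likely range from 70 nM to 420 nM.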

Compound 3, half-maximal effective concentration: 136 nM
Compound 3: middle estimate off by 1.3-fold (0.10 log units), on the high side; the measured number falls inside the stated range.
By their numbers in this assay, from the lowest: compounds 3, 1 and 2 (each within the scatter of the next).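

On an oxygen on a saturated carbon, the exchange of 3-carboxy-4-fluorophenyl for 3-carboxy-2-methylphenyl now has a direct reading in this assay, a 1.5-fold lower number from compound 2 to compound 3 (0.18 log units; within the scatter), so with neopentyl kept on the carbonyl carbon these two groups are not told apart. The other place, the carbonyl carbon, gains its first direct reading as well: neopentyl in place of isopropyl gives a 1.1-fold lower number from compound 1 to compound 3 (0.04 log units; within the scatter), so with 3-carboxy-2-methylphenyl kept, this exchange also leaves the compounds unseparated, and the similar numbers of compound 1 and compound 2, which differ in both places, now rest on two single steps that each stay within the scatter. No accompanying measurement offers an explanation for either result.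

On these data alone, each exchange has been read only once and against a single background, so it remains open whether 3-carboxy-4-fluorophenyl would behave the same way alongside isopropyl on the carbonyl carbon. Also open, as far as these compounds go, is whether a group of another kind, such as cyclopropyl or phenyl on the carbonyl carbon, or an unsubstituted phenyl on the oxygen, would move the number beyond the scatter.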